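This account rests on a few compounds, and the source may have more. Where it says the series, first, only, none or still open, it means among the compounds named here.

Measured in an ADME assay on HUVEC cells (Homo sapiens) for antiproliferative activity, read by resazurin assay, with a stated time of 72 h; on this read-out lower numbers stand for stronger inhibition of growth and higher numbers for weaker inhibition of growth:
- compound 1 `CCCCCCCCCCCC/C=C\N(NC(=O)COC)C(=O)CCCCCCCCC`: 70700 nM
- compound 2 `CCCCCCCCCCCC/C=C\N(NC(=O)COC)C(=O)OC(C)(C)C`: 15800 nM

Within the data shown here, of these two numbers, compound 2 has the lower at 15800 nM, and compound 1 is the only neighbour. Next in the series is compound 3 `CCCCCCCC/C=C\N(NC(=O)COC)C(=O)OC(C)(C)C`, which keeps the tert-butoxy group of compound 2 and shortens the chain on the double bond: hydrogen in place of butyl on a saturated chain carbon, eight bonds along the chain from a double-bonded chain carbon.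

Among the measured compounds shown here, only one measured step is available, a 4.5-fold lower number from compound 1 to compound 2 (0.65 log units; beyond the scatter). It is modest and lies beyond the scatter, but it comes from tert-butoxy in place of nonyl on a carbonyl carbon, a different place from the present change. For the measured compounds named here, no measured step shows what hydrogen in place of butyl does on this chain, so the direction remains open. The size of a 4.5-fold lower number from compound 1 to compound 2 (0.65 log units; beyond the scatter) serves only as a loose guide to how far this assay might move, and a step of about that size either way stays possible. The expected change is small, a 1.3-fold higher number from compound 2 to compound 3 (0.10 log units; within the scatter). For compound 3 the estimated value is 20000 nM, with an expected range of 6000 nM to 65000 nM.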

Compound 3, concentration for 50% growth inhibition: 85500 nM
Compound 3: the middle estimate sits 4.3-fold (0.63 log units) below what was measured, outside the stated range (above it).
By their numbers in this assay, from the lowest: compound 2; then compounds 1 and 3 (each within the scatter of the next).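

In this assay the chain on the double bond proves to matter: hydrogen in place of butyl at this place gives a 5.4-fold higher number from compound 2 to compound 3 (0.73 log units; beyond the scatter) with the tert-butoxy group held constant, so this modest step belongs to the chain alone. The read-out therefore answers to this place as well as to the carbonyl substituent, the only place with an earlier measured step, where the change gave a 4.5-fold lower number from compound 1 to compound 2 (0.65 log units; beyond the scatter) in the same assay. No measurement on hand accounts for the loss of growth inhibition on shortening the chain.

The chain lengths shown give no shape for this relation, so a chain of intermediate length or a longer chain than that of compound 2 could fall on either side of it. Also open, on these data alone, is whether the same shortening acts alike with the nonyl carbonyl of compound 1 in place of tert-butoxy, and what an amine or a carboxylic acid at this place on the chain would do to the read-out.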